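This account rests on a few compounds, and the source may have more. Where it says the series, first, only, none or still open, it means among the compounds named here.

In an assay on isolated protein for inhibition of complement C1r subcomponent (Homo sapiens) (a lower number here means a stronger inhibitor, a higher number a weaker inhibitor), compound 1 `O=c1oc(-c2ccc(I)cc2)nc2ccccc12` gives only a limit, > 62500 nM. Compound 2 `O=c1oc(-c2ccccc2I)nc2cc(Cl)ccc12` likewise returns only a limit in this assay, > 62500 nM. Compound 3 `O=c1oc(-c2ccccc2I)nc2cc(Cl)c(Cl)cc12` also sits at a limit, > 62500 nM. Compound 2 therefore stands at the limit of this assay, as do the two other values shown; all three values sit at the limit of > 62500 nM in this assay, at which 3 of the 3 values shown sit. The step that the two limits leave unreadable from compound 2 to compound 3 is unreadable, both of its ends being limits. Compound 4 `O=c1oc(-c2ccccc2I)nc2cc([N+](=O)[O-])ccc12` differs from compound 2 by nitro in place of chloro on an aromatic carbon. Going by the values given here, no measured step bears on nitro in place of chloro, and the one measured step, chloro in place of hydrogen, is itself unreadable. There is thus no measured basis for expecting a step of any size or direction in this assay beyond the scatter. Compound 4 is therefore expected to remain at or near the limit, with an estimate of 100000 nM ranging from 30000 nM to 300000 nM. The step this estimate means, a step that the limit leaves unreadable from compound 2 to compound 4, is expected to be small.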

Compound 4, half-maximal inhibitory concentration: 22000 nM
Beside the measured number, compound 4's estimate is 4.5-fold (0.66 log units) above it; the measured number lies below the stated range.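

In this assay, nitro in place of chloro on this aromatic carbon, meta to a fused ring and para to a fused ring, gives an at least 2.8-fold lower number from compound 2 to compound 4 (0.45 log units; beyond the scatter). Going by these compounds alone, this shows that a change at this position can move the compound off the limit, which the earlier compounds could not show, as the only step among them cannot be read. Compound 4 is the one compound shown that returns a number rather than a limit: the limit of > 62500 nM in this assay, at which 3 of the 4 values shown sit.

The compounds shown leave open whether this response is particular to nitro or would also appear with an amine, a nitrile or a methoxy group on the same carbon. They also leave open whether nitro would give a measurable value on the core of compound 1.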